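Swapping the Aryl Group on the Sulfur of Compound 3

The compounds below may be only part of what the source reports. "The series", "measured", "known", "first", "only" and "open" are said of these compounds alone.

The three measured compounds share one core and differ only in the group attached to it. Compound 1 `COc1ccc(CNc2nc3cc(N)cc(N)c3nc2-c2ccccc2)cc1OC` gives 8710 nM in a functional assay on SK-MEL-2 cells (Homo sapiens) for inhibition, read by sulforhodamine B assay, with a stated time of 48 h; a higher number here means a weaker inhibitor of growth, a lower number a stronger inhibitor of growth. Compound 2 `Nc1cc(N)c2nc(-c3ccccc3)c(NCc3ccc(F)cc3)nc2c1` gives 5250 nM in this assay, and the change of a 1.7-fold lower number from compound 1 to compound 2 (0.22 log units; within the scatter) stays within the scatter. Compound 3 `Nc1cc(N)c2nc(-c3ccccc3)c(Sc3ccc(Cl)c(Cl)c3)nc2c1` gives 6170 nM in this assay; the move of a 1.2-fold higher number from compound 2 to compound 3 (0.07 log units; within the scatter) is likewise within the scatter, so compound 3 stands with the other two, none of which can be told apart on these numbers.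

Compound 4 `Nc1cc(N)c2nc(-c3ccccc3)c(Sc3ccc(F)cc3)nc2c1` has not yet been measured. It differs from compound 3 by 4-fluorophenyl in place of 3,4-dichlorophenyl on a sulfur. For the measured compounds named here, the nearest precedent is the step from compound 1 to compound 2, where a differently substituted aryl group on the saturated chain carbon replaced a 3,4-dimethoxyphenyl and moved the number only within the scatter; the step from compound 2 to compound 3, which changed the linker rather than the aryl group, was also within the scatter. Going by the values given here, no measured step shows an aryl swap on the sulfur itself. On this basis compound 4 is expected to show a step of a 1.0-fold lower number from compound 3 to compound 4 (0.01 log units; within the scatter), that is nothing beyond the scatter. Compound 4 is therefore estimated at 6000 nM, with a range from 2500 nM to 15000 nM.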

Compound 4, concentration for 50% growth inhibition: 38000 nM
The estimate for compound 4 lay 6.3-fold (0.80 log units) below the measured number; the whole stated range lies below it.
By their numbers in this assay, from the lowest: compounds 2, 3 and 1 (each within the scatter of the next); then compound 4.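

For the compounds shown here, on the sulfur, the aryl group is the first place where a swap moves the number in this assay beyond the scatter: 4-fluorophenyl in place of 3,4-dichlorophenyl gives (a 6.2-fold higher number from compound 3 to compound 4 (0.79 log units; beyond the scatter)), whereas the aryl swap on the saturated chain carbon stayed within it (a 1.7-fold lower number from compound 1 to compound 2 (0.22 log units; within the scatter)). Replacing (4-fluorobenzyl)amino with a sulfur-linked group can therefore end either way, since (4-fluorophenyl)sulfanyl gives (a 7.2-fold higher number from compound 2 to compound 4 (0.86 log units; beyond the scatter)), while (3,4-dichlorophenyl)sulfanyl stayed within the scatter (a 1.2-fold higher number from compound 2 to compound 3 (0.07 log units; within the scatter)). Nothing available accounts for this difference between the two aryl groups on the sulfur.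

The step from compound 3 to compound 4 removes both chlorines and adds a fluorine at once, so the compounds shown do not separate these changes; a 4-chlorophenyl, a 3-chlorophenyl or an unsubstituted phenyl on the sulfur would help to do so. They also leave open whether a 3,4-dichlorobenzyl group on the amino nitrogen would differ from the 4-fluorobenzyl group of compound 2, or whether the aryl group matters only on the sulfur.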